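The source may hold more compounds than are shown below. What is called first, only, known or untested is meant among the compounds shown, and "the series" means these compounds.

Going by the values given here, compound 2, with the structure `COc1cc(OC)c(-c2nc3cc(/C=C4\SC(=O)NC4=O)ccc3[nH]2)cc1OC`, stands second highest of the three numbers so far in a functional assay on PC-3 cells (Homo sapiens) for inhibition, read by MTT assay, with a stated time of 48 h; a lower number here means a stronger inhibitor, a higher number a weaker inhibitor: in this assay compound 2 gives 6320 nM. Its nearest neighbour is compound 1, `COc1ccc(-c2nc3cc(/C=C4\SC(=O)NC4=O)ccc3[nH]2)cc1OC`, which in this assay gives 8720 nM; the move a 1.4-fold lower number from compound 1 to compound 2 (0.14 log units; within the scatter) is a methoxy in place of hydrogen on an aromatic carbon. Furthest away is compound 3, `COc1cc(-c2nc3cc(/C=C4\SC(=O)N(Cc5ccccc5)C4=O)ccc3[nH]2)cc(OC)c1OC`, which in this assay gives 2500 nM; compound 3 differs from compound 2 in more than one place, so only the two values themselves can be compared.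

Compound 4, `COc1cc(OC)c(-c2nc3cc(/C=C4\SC(=O)N(Cc5cccc(C)c5)C4=O)ccc3[nH]2)cc1OC`, differs from compound 2 by 3-methylbenzyl in place of hydrogen on an amide-type nitrogen in a ring. Among the compounds with values here, no measured step concerns this nitrogen alone; the only step on record, from compound 1 to compound 2, is at another place and lies within the scatter. Compound 3 carries a benzyl on the same nitrogen and shows the lowest number of the three, which is taken as the only pointer toward a lower number for compound 4, of modest size.

Compound 4 is therefore expected to give about 3000 nM in this assay, within a range from 1200 nM to 7500 nM, which would be an estimated step of a 2.1-fold lower number from compound 2 to compound 4 (0.32 log units; beyond the scatter).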

Compound 4, half-maximal inhibitory concentration: 630 nM
For compound 4 the middle estimate is 4.8-fold (0.68 log units) above the measured one; the measured number lies below the stated range.
By their numbers in this assay, from the lowest: compound 4; then compound 3; then compounds 2 and 1 (each within the scatter of the next).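

In this assay, going by these compounds alone, replacing the hydrogen on the amide-type nitrogen of the five-membered ring with 3-methylbenzyl gives a 10-fold lower number from compound 2 to compound 4 (1.00 log units; beyond the scatter), the first step that isolates a change at this position. The only earlier step, a 1.4-fold lower number from compound 1 to compound 2 (0.14 log units; within the scatter), lies at another place and within the scatter, so this nitrogen, two ring bonds from the ring sulfur, is the one place shown where a single change moves the number beyond the scatter. Nothing at hand accounts for the size of this step.

On these data alone, how much of the step belongs to the methyl and how much to the benzyl itself remains open, as compound 3 differs from compound 4 in more than one place. Also open, as far as these compounds go, is how a simple methyl, a longer alkyl chain or a chain ending in an amine or carboxylic acid would read on this nitrogen.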